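Working notes: from compound 3 to compound 4

The source may report more compounds than this note shows. Statements on the series, on what has been measured and on what is new or still open speak of the compounds shown alone.

In a functional assay on Caco-2 cells (Homo sapiens) for inhibition, read by MTT assay, with a stated time of 48 h, tested at 10 uM (a higher number here means more inhibition of growth at the concentration tested, a lower number less inhibition of growth), compound 1 `Cc1cc(=O)c2c(O)c(CN3CCCC3)c(O)c([C@H]3CCN(C)C[C@H]3O)c2o1` gives 22% at the single concentration tested, compound 2 `Cc1cc(=O)c2c(O)c(CN3CCCC3CO)c(O)c([C@H]3CCN(C)C[C@H]3O)c2o1` gives 19% and compound 3 `CCOC(=O)N1CCN(Cc2c(O)c([C@H]3CCN(C)C[C@H]3O)c3oc(C)cc(=O)c3c2O)CC1` gives 18% on the same core. Compound 3 lies within the scatter of both other compounds, so no order can be read among the three.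

Compound 4 `Cc1cc(=O)c2c(O)c(CN(C(C)C)C(C)C)c(O)c([C@H]3CCN(C)C[C@H]3O)c2o1` is the next structure to be read. Its difference from compound 3 is diisopropylamino in place of 4-(ethoxycarbonyl)piperazin-1-yl on a saturated chain carbon bound to an aromatic carbon with diisopropylamino in place of 4-(ethoxycarbonyl)piperazin-1-yl on a saturated chain carbon bound to an aromatic carbon.

Within the data shown here, two measured steps change the group at this same place, and both are small: a number 4 percentage points lower from compound 1 to compound 3 (within the scatter) and a number 1 percentage points lower from compound 2 to compound 3 (within the scatter) in the series so far. The hydroxymethyl change is also small, with a number 3 percentage points lower from compound 1 to compound 2 (within the scatter) as its measured size. Diisopropylamino has no ring, while all three measured groups at this place do, so the data hold no direct precedent and the range stays wide.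

No change beyond the scatter is expected in this assay for this replacement. The expected size is a number 3 percentage points higher from compound 3 to compound 4 (within the scatter) on this reasoning. For compound 4 the estimate is 21% with 9% to 35% as the expected range.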

Compound 4, percent growth inhibition at one concentration: 22%
Compound 4: middle estimate off by 1 percentage points, on the low side; the measured number falls inside the stated range.
By their numbers in this assay, from the lowest: compounds 3, 2, 1 and 4 (each within the scatter of the next).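

In this assay, the open-chain diisopropylamino group gives a number 4 percentage points higher from compound 3 to compound 4 (within the scatter) and a number 3 percentage points higher from compound 2 to compound 4 (within the scatter) and no change at the digits printed from compound 1 to compound 4 (within the scatter), so all three replacements of a ring-bearing group stay inside the usual scatter. The earlier steps shown here only exchanged one ring for another at this place on a saturated chain carbon bound to an aromatic carbon; this step shows that the number does not depend on a ring being present there, nor on the second ring nitrogen and the ethoxycarbonyl of 4-(ethoxycarbonyl)piperazin-1-yl, across these four compounds. No measurement shown here gives a reason for this flat reading.

Still open, on these data alone, is whether any group at this place can shift growth inhibition beyond the scatter, since all four compounds carry a fully substituted amine nitrogen there. A primary amine or a carboxylic acid in that place, or a longer chain between the amine nitrogen and the aromatic carbon, would test how far this flat reading extends on the shared core.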